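Arylidene thiazolidinone series: cytotoxicity on breast cancer cells

This account rests on a few compounds, and the source may have more. Where it says the series, first, only, none or still open, it means among the compounds named here.

Measured compounds:
- compound 1 `Cc1ccc(N2C(=O)CS/C2=N\c2csc(-c3ccc(Cl)cc3)c2)cc1`: "not determined" (no result reported)
- compound 2 `CN(C)c1ccc(/C=C2\S/C(=N\c3nc(-c4ccc(Cl)cc4)cs3)NC2=O)cc1`: 300 nM

Among the compounds with values here, compound 2 is the only member of the series with a reported number. In a functional assay on MDA-MB-231 cells (Homo sapiens) for cytotoxicity, read by MTT assay, with a stated time of 72 h (on this read-out lower numbers stand for stronger inhibition and higher numbers for weaker inhibition), compound 2 gives 300 nM. In this assay, within the data shown here, compound 1 gives "not determined" (no result reported), so no step between measured compounds can be computed and compound 2 stands alone as the sole reference point.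

Compound 3 `O=C1N/C(=N/c2nc(-c3ccc(Cl)cc3)cs2)S/C1=C\c1ccc2ccccc2c1` is not yet measured. It differs from compound 2 by naphthalen-2-yl in place of 4-(dimethylamino)phenyl on a double-bonded chain carbon bound to a double-bonded ring carbon. Among the measured compounds shown here, with no measured step available, the direction of the change is open; a modest shift in either direction, or none beyond the usual scatter, is equally plausible from the data in hand. For compound 3 in this assay the expected value is 600 nM (range 150 nM to 2500 nM), which corresponds to an estimated step of a 2.0-fold higher number from compound 2 to compound 3 (0.30 log units; within the scatter).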

Compound 3, half-maximal inhibitory concentration: 900 nM
The estimate for compound 3 lay 1.5-fold (0.18 log units) below the measured number; low and high end bracket the measured number.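

Within the data shown here, this is the first readable step: in this assay, naphthalen-2-yl in place of 4-(dimethylamino)phenyl on a double-bonded chain carbon bound to a double-bonded ring carbon gives a 3.0-fold higher number from compound 2 to compound 3 (0.48 log units; beyond the scatter), beyond the usual scatter. The number at this position therefore depends on the aromatic group it carries, although a single change cannot show a trend. The change removes the nitrogen and the hydrogen-bond acceptor of the leaving group and brings in a second six-membered aromatic ring, and nothing measured separates these differences as the source of the step.

As far as these compounds go, whether the loss of the dimethylamino group or the gain of the second ring matters more remains open, and plain phenyl or 4-methoxyphenyl at this position would bear on that. Compound 1 has no result, so it adds nothing to the comparison.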